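Amide aryl swap in a shared-core series: solubility notes

The compounds below may be only part of what the source reports. "The series", "measured", "known", "first", "only" and "open" are said of these compounds alone.

Measured so far:
compound 1 `COc1ccc2nc(C)c(NC(=O)C(=O)Nc3cc(C)cc(C)c3)c(O)c2c1` — 10000 nM
compound 2 `COc1ccc2nc(C)cc(OCC(=O)Nc3cc(C)ccc3OC)c2c1` — 9500 nM
compound 3 `COc1ccc2nc(C)cc(OCC(=O)Nc3cc(OC)c(OC)c(OC)c3)c2c1` — 34000 nM

In a physicochemical assay for solubility, in phosphate buffer, measured as kinetic solubility, with a stated time of 1 h, at pH 7.4 (a lower number here means a less soluble compound, a higher number a more soluble compound), compound 2 gives 9500 nM, the lowest of the three numbers. Compound 1 with 10000 nM lies within the scatter of that figure, so no order between the two is claimed; compound 3 at 34000 nM stands beyond the scatter above compound 2.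

Compound 4 `COc1ccc2nc(C)cc(OCC(=O)Nc3nc(C)c(C)s3)c2c1` is not yet measured in this assay. It differs from compound 2 in one place: 4,5-dimethyl-1,3-thiazol-2-yl in place of 2-methoxy-5-methylphenyl on an amide-type nitrogen. Within the data shown here, no step between measured compounds covers a change of this kind, so the series itself gives no size for it. The expectation is a modest step downward, possibly none beyond the scatter, a 1.6-fold lower number from compound 2 to compound 4 (0.20 log units; within the scatter). For compound 4 the estimated value in this assay is 6000 nM, with a range from 2000 nM to 18000 nM.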

Compound 4, solubility: 31500 nM
Beside the measured number, compound 4's estimate is 5.3-fold (0.72 log units) below it; measured number above the stated range.
By their numbers in this assay, from the lowest: compounds 2 and 1 (each within the scatter of the next); then compounds 4 and 3 (each within the scatter of the next).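

In this assay, among these compounds, the group on the amide-type nitrogen proves able to shift the number: 4,5-dimethyl-1,3-thiazol-2-yl in place of 2-methoxy-5-methylphenyl gives a 3.3-fold higher number from compound 2 to compound 4 (0.52 log units; beyond the scatter) and provides the first one-place step, beyond the scatter. The change replaces a six-membered carbon ring with a five-membered ring holding two hetero atoms, and this single step cannot separate the ring from its substituents. No measurement at hand gives a reason for the step.

Open, on these data alone, is how much of the step depends on the two methyl groups on the 1,3-thiazol-2-yl ring. Also open, as far as these compounds go, is how an amine or a carboxylic acid on that ring would read.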